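Alkyl changes at the oxygen next to the carbonyl

A few compounds are considered here, and "the series" means these few. Any claim that something is new, unique, unknown or untested is made for them only; others in the source may bear on it.

Values in an assay for inhibition of serine/threonine-protein kinase PAK 4 (Homo sapiens), read by FRET and Z'-LYTE, with a stated time of 60 min, tested at 0.5 uM, in the presence of a further agent that is not named here; on this read-out higher numbers stand for a stronger effect at the one concentration tested and lower numbers for a weaker effect:
compound 1 `CC(C)COC(=O)N1CCN(C(=O)c2nc(Nc3cc(C4CC4)[nH]n3)c3cc(Cl)ccc3n2)C[C@H]1C`: 0.8%
compound 2 `C[C@@H]1CN(C(=O)c2nc(Nc3cc(C4CC4)[nH]n3)c3cc(Cl)ccc3n2)CCN1C(=O)OC(C)(C)C`: 0.1%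
compound 3 `C[C@@H]1CN(C(=O)c2nc(Nc3cc(C4CC4)[nH]n3)c3cc(Cl)ccc3n2)CCN1C(=O)OCc1ccccc1`: 4.4%

Compound 1 stands second highest of the three, and all separations are small: a number 0.7 percentage points lower from compound 1 to compound 2 (within the scatter), a number 3.6 percentage points higher from compound 1 to compound 3 (within the scatter) and a number 4.3 percentage points higher from compound 2 to compound 3 (within the scatter), each within the scatter. Every one of these steps exchanges the group on the oxygen next to the carbonyl, so they bear directly on compound 4 `CC(C)OC(=O)N1CCN(C(=O)c2nc(Nc3cc(C4CC4)[nH]n3)c3cc(Cl)ccc3n2)C[C@H]1C`, which differs from compound 1 by isopropyl in place of isobutyl on an oxygen next to a carbonyl group. Since a tert-butyl, an isobutyl and a benzyl at this position all give numbers within the scatter of one another, no step beyond the scatter is expected in this assay for a further small alkyl. Compound 4 is therefore estimated at 1.5%, with a range of -8% to 11%. The expected step is a number 0.7 percentage points higher from compound 1 to compound 4 (within the scatter).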

Compound 4, a percentage reported as inhibition, at one concentration (the size of the read-out at that concentration, not a potency): 26.9%
For compound 4 the middle estimate is 25.4 percentage points below the measured one; measured number outside the range, above it.
By their numbers in this assay, from the lowest: compounds 2, 1 and 3 (each within the scatter of the next); then compound 4.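

Working through this assay, this position turns out not to be flat as the earlier compounds suggested: there is a number 26.1 percentage points higher from compound 1 to compound 4 (beyond the scatter) with isopropyl in place of isobutyl, a number 22.5 percentage points higher from compound 3 to compound 4 (beyond the scatter) with isopropyl in place of benzyl, and a number 26.8 percentage points higher from compound 2 to compound 4 (beyond the scatter) with hydrogen in place of methyl on the saturated chain carbon. Among these four compounds, a change of a single carbon in the group on the oxygen is thus enough to separate compound 4 from compound 1 and compound 2. Nothing available accounts for this step.

Open, on these data alone, is whether ethyl or cyclobutyl on the same oxygen would keep the higher number. Also open, as far as these compounds go, is whether an amine in place of that oxygen would keep it.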